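Purine series with a benzamide arm: notes on compound 4

This account rests on a few compounds, and the source may have more. Where it says the series, first, only, none or still open, it means among the compounds named here.

Three members of the series have been run in a functional assay on NCI-H460 cells (Homo sapiens) for antiproliferative activity, read by CCK-8 assay, with a stated time of 72 h, tested at 8 uM; on this read-out lower numbers stand for a weaker effect and higher numbers for a stronger effect at the one concentration tested. Compound 1 `CC(C)n1cnc2c(Nc3ccccc3)nc(NCOCc3ccc(/C=C/C(=O)Nc4ccccc4N)cc3)nc21` gives 53.1% and compound 3 `Nc1ccccc1NC(=O)c1ccc(COCNc2nc(Nc3cccc(Cl)c3)c3ncn(C4CCCC4)c3n2)cc1` gives 49.2%. Compound 2 `CC1CCN(c2nc(Cl)nc3c2ncn3Cc2ccc(/C=C/C(=O)Nc3ccccc3N)cc2)CC1` gives 10.8%, the lowest of the three numbers; the gap to compound 3 and the gap to compound 1 both lie beyond the usual scatter of this assay, so compound 2 stands clearly below the other two measured compounds. For the measured compounds named here, no two of the measured compounds differ in a single place, so no measured step is available.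

Compound 4 `Nc1ccccc1NC(=O)/C=C/c1ccc(Cn2cnc3c(NCc4ccccc4)nc(Cl)nc32)cc1` has not yet been measured. It differs from compound 2 in one place: benzylamino in place of 4-methylpiperidin-1-yl on an aromatic carbon. The chloro group and the rest of the core of compound 2 are retained.

For this assay an increase is expected, of moderate size but beyond the scatter, given that compound 2 gives 10.8% while compound 1, carrying a substituent with 1 hydrogen-bond donor at the corresponding position, gives 53.1% and compound 3, carrying one too, gives 49.2%. Those two compounds differ from compound 4 in further places, so the comparison is loose. Compound 4 is estimated at 30%, with a range from 10% to 55%; the expected step is a number 19.2 percentage points higher from compound 2 to compound 4 (beyond the scatter).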

Compound 4, a percentage reported as inhibition, at one concentration (the size of the read-out at that concentration, not a potency): 49.1%
Estimate against measurement, compound 4: 19.1 percentage points below; the measured number falls inside the stated range.
By their numbers in this assay, from the lowest: compound 2; then compounds 4, 3 and 1 (each within the scatter of the next).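

For the compounds shown here, this is the first single-place step: in this assay, benzylamino in place of 4-methylpiperidin-1-yl gives a number 38.3 percentage points higher from compound 2 to compound 4 (beyond the scatter), with the chloro group and the rest of the core retained. The position, on an aromatic carbon next to the ring nitrogen, can therefore carry a large change in this read-out on its own, and the low number of compound 2 is tied to the 4-methylpiperidin-1-yl group in this setting rather than to the chloro-bearing core as a whole. No measurement shown explains the step, and the change alters several features at once: the non-aromatic ring gives way to an aromatic one, and the entering group carries a hydrogen-bond donor where the leaving group has none.

From the compounds shown here alone, what remains open is which of these features matters: a cyclohexylamino group would keep the amine hydrogen without the aromatic ring, whereas an N-methylbenzylamino group would keep the aromatic ring without that hydrogen. Going by these compounds, whether the step holds with a methoxy group in place of the chloro group also remains open.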